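Dichloro aniline variant of the fused core, expected inhibition

The compounds below may be only part of what the source reports. "The series", "measured", "known", "first", "only" and "open" are said of these compounds alone.

Measured so far:
compound 1, `Cc1n[nH]c2ccc(-c3nc4cnc(N5CCN(C)CC5)cn4c3Nc3ccccc3F)cc12`, 0%
compound 2, `Cc1n[nH]c2ccc(-c3nc4cnc(N5CCC(C)CC5)cn4c3Nc3ccc(Cl)cc3)cc12`, 28%
compound 3, `Cc1n[nH]c2ccc(-c3nc4cnc(N5CCN(C)CC5)cn4c3Nc3ccccc3)cc12`, 0%

In a functional assay on MV4-11 cells (Homo sapiens) for inhibition, with a stated time of 120 h, tested at 10 uM (a lower number here means less inhibition, a higher number more inhibition at the concentration tested (going by the name of the read-out)), compound 3 gives 0%, level with compound 1 at the digits shown and together with it the lowest of the three numbers. Compound 2 gives 28%, higher than compound 3, but compound 2 differs from compound 3 in two places at once, the saturated ring on the core as well as the chloro on the anilino ring, so its number cannot be assigned to either change alone.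

Compound 4, `Cc1n[nH]c2ccc(-c3nc4cnc(N5CCN(C)CC5)cn4c3Nc3ccc(Cl)cc3Cl)cc12`, is not yet measured in this assay. Its difference from compound 3 is 2,4-dichlorophenyl in place of phenyl on a nitrogen on an aromatic ring.

For the measured compounds named here, the only single step on the anilino ring is no change at the digits printed from compound 1 to compound 3 (within the scatter), where hydrogen in place of fluoro left the number unchanged. Nothing measured isolates a chloro on that ring. Going by the values given here, the step of a number 12 percentage points higher from compound 3 to compound 4 (beyond the scatter) is therefore expected to be small, with a wide allowance upward because compound 2, the only chloro-bearing compound, gives 28%. Compound 4 is estimated at 12%, with a range from 0% to 40%.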

Compound 4, a percentage reported as inhibition, at one concentration (the size of the read-out at that concentration, not a potency): 78.8%
Compound 4: middle estimate off by 66.8 percentage points, on the low side; the whole stated range lies below it.
By their numbers in this assay, from the lowest: compounds 1 and 3 (each within the scatter of the next); then compound 2; then compound 4.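

Working notes on the anilino position: in this assay this position, on the nitrogen on an aromatic ring of the shared core, can carry a large change, shown by a number 78.8 percentage points higher from compound 3 to compound 4 (beyond the scatter) on going from phenyl to 2,4-dichlorophenyl, whereas the earlier step at this position, no change at the digits printed from compound 1 to compound 3 (within the scatter), gave no sign of this. The step of a number 78.8 percentage points higher from compound 1 to compound 4 (beyond the scatter), with 2,4-dichlorophenyl in place of 2-fluorophenyl, has the same size, so the rise appears from either of the two low starting compounds, and a single fluoro on that ring does not stand in for the two chlorines. Nothing available bears on why the number rises this far.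

Open, going by these compounds, is whether the rise needs both chlorines or comes mainly from one of them, and whether 2,4-difluorophenyl or 2,4-dimethylphenyl on the same nitrogen would behave alike. Compound 2 also carries a chloro but differs from compound 4 in more than one place, so it cannot settle this, and a reading at one concentration in this assay says nothing about potency.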